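Replacing dimethylamino with ((4-nitrophenyl)carbonyl)oxy on compound 1

A few compounds are considered here, and "the series" means these few. Any claim that something is new, unique, unknown or untested is made for them only; others in the source may bear on it.

Compound 1 (`CC(C)=CCC[C@]1(C)/C=C/[C@@H](OC(=O)C=C(C)C)[C@](C)(O)/C=C/C(=O)/C(CN(C)C)=C\C1`) is the reference point of this small series. For the measured compounds named here, in a functional assay on SW480 cells (Homo sapiens) for antiproliferative activity, read by MTT assay, with a stated time of 48 h (a lower number here means a stronger inhibitor, a higher number a weaker inhibitor), compound 1 gives 480 nM as the only exact number so far. For compound 2 (`CC(C)=CCC[C@]1(C)/C=C/[C@@H](OC(=O)C=C(C)C)[C@](C)(O)CCC(=O)/C(CO)=C\C1`) the reading in this assay is only a limit (> 40000 nM). Compound 3 (`CC(C)=CCC[C@]1(C)/C=C/[C@@H](OC(=O)C=C(C)C)[C@](C)(O)/C=C/C(=O)/C(COC(=O)c2ccc([N+](=O)[O-])cc2)=C\C1`) has not yet been measured. It keeps the core of compound 1 but carries ((4-nitrophenyl)carbonyl)oxy in place of dimethylamino on a saturated chain carbon bound to a double-bonded ring carbon. Going by the values given here, no measured pair shows this change, so the expectation starts from compound 1 at 480 nM and carries wide uncertainty. A weakening beyond the scatter is expected in this assay, with an estimated step of a 4.2-fold higher number from compound 1 to compound 3 (0.62 log units; beyond the scatter) as its size. Compound 3 is estimated at 2000 nM with 400 nM and 12000 nM as the expected lower and upper ends of the range.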

Compound 3, half-maximal inhibitory concentration: 570 nM
The estimate for compound 3 lay 3.5-fold (0.55 log units) above the measured number; the measured number falls inside the stated range.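

In this assay, putting ((4-nitrophenyl)carbonyl)oxy in place of dimethylamino on a saturated chain carbon bound to a double-bonded ring carbon gives a 1.2-fold higher number from compound 1 to compound 3 (0.07 log units; within the scatter). For the compounds shown here, this is the first single-place change read at this carbon, and it shows that, on the core of compound 1, the amine nitrogen of dimethylamino is not required for a reading of this order: an ester bearing a six-membered aromatic ring serves as well. Nothing measured here gives a cause for this result.

Compound 2 stands only as a limit, > 40000 nM, and it differs from compound 1 in more than one place. From the compounds shown here alone, it remains open whether a morpholine, an acetyl ester or a carboxylic acid on this carbon would read like compound 1, and whether the nitro group of compound 3 plays any part.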